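Swapping the Aryl Substituent on the Ester of Compound 3

The source may hold more compounds than are shown below. What is called first, only, known or untested is meant among the compounds shown, and "the series" means these compounds.

Compound 3 `COC(OC)C1=C(C(=O)OC/C=C/c2ccc(Cl)cc2)C(c2cccc(Cl)c2)C(C(=O)O)=C(C)N1` gives 1400 nM in an assay on thoracic aorta for inhibition of Voltage-gated L-type calcium channel (Rattus norvegicus) (on this read-out higher numbers stand for weaker inhibition and lower numbers for stronger inhibition), the second highest of the three numbers; compound 1 `COC(OC)C1=C(C(=O)OC/C=C/c2ccccc2)C(c2cccc(Cl)c2)C(C(=O)O)=C(C)N1` gives 8100 nM and compound 2 `CCC1=C(C(=O)OC/C=C/c2ccccc2)C(c2cccc(Cl)c2)C(C(=O)O)=C(C)N1` gives 7 nM. Compound 4 `COc1ccccc1/C=C/COC(=O)C1=C(C(OC)OC)NC(C)=C(C(=O)O)C1c1cccc(Cl)c1` differs from compound 3 by 2-methoxyphenyl in place of 4-chlorophenyl on a double-bonded chain carbon bound to a double-bonded chain carbon. The step of a 5.8-fold lower number from compound 1 to compound 3 (0.76 log units; beyond the scatter) is the one that bears on this change, as it concerns the same ring; the step of a 1200-fold lower number from compound 1 to compound 2 (3.06 log units; beyond the scatter) lies elsewhere and offers little guidance. Compound 4 lacks the chloro on that ring, so its number is expected to move back toward the value of compound 1, 8100 nM. The expected step is a 2.5-fold higher number from compound 3 to compound 4 (0.40 log units; beyond the scatter). Compound 4 is estimated at 3500 nM, with a range from 900 nM to 14000 nM.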

Compound 4, half-maximal inhibitory concentration: 5900 nM
For compound 4 the middle estimate is 1.7-fold (0.23 log units) below the measured one; the measured number falls inside the stated range.
By their numbers in this assay, from the lowest: compound 2; then compound 3; then compounds 4 and 1 (each within the scatter of the next).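

In this assay, the change of 4-chlorophenyl to 2-methoxyphenyl gives a 4.2-fold higher number from compound 3 to compound 4 (0.62 log units; beyond the scatter), so this methoxy-bearing ring does not keep the standing of the chloro-bearing one. The step of a 1.4-fold lower number from compound 1 to compound 4 (0.14 log units; within the scatter) places compound 4 level with compound 1, so at this position methoxy shows no measurable gain over hydrogen. Nothing given here accounts for this difference. The swap alters both the group and where it sits on the ring, and the compounds shown cannot separate the two. On these data alone, whether a fluoro or an amine on that ring would do better remains open.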